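A few compounds are considered here, and "the series" means these few. Any claim that something is new, unique, unknown or untested is made for them only; others in the source may bear on it.

Of the compounds shown here, three built on one shared core have been tested in an ADME assay on MCF-10A cells (Homo sapiens) for cytotoxicity, read by MTT assay, with a stated time of 48 h; on this read-out lower numbers stand for stronger inhibition and higher numbers for weaker inhibition. Compound 1 `COc1ccc(CNC(=O)c2cc3cc(OC)c(OCCCOc4no[n+]([O-])c4S(=O)(=O)c4ccccc4)cc3oc2=O)cc1` gives 5950 nM. Compound 2 `COc1cc2cc(C(=O)NCCCc3ccc(F)cc3)c(=O)oc2cc1OCCCOc1no[n+]([O-])c1S(=O)(=O)c1ccccc1` gives 8920 nM. Compound 3 `COc1cc2cc(N)c(=O)oc2cc1OCCCOc1no[n+]([O-])c1S(=O)(=O)c1ccccc1` gives 6450 nM. Among these three numbers compound 3 holds the second highest place, yet every gap between them lies within the scatter, so no order of strength can be read from them.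

Compound 4 `COc1cc2cc(C(=O)NCc3ccccc3)c(=O)oc2cc1OCCCOc1no[n+]([O-])c1S(=O)(=O)c1ccccc1` has not yet been measured in this assay. It differs from compound 3 in one place: benzylcarbamoyl in place of amino on an aromatic carbon. Within the data shown here, two measured steps bear on this change. The closest is the reverse of the one in which an amino group replaced a related carbamoyl group: a 1.1-fold higher number from compound 1 to compound 3 (0.04 log units; within the scatter). The other step, which swapped one chain on the amide nitrogen for another, is a 1.5-fold higher number from compound 1 to compound 2 (0.18 log units; within the scatter). Neither step moved the number beyond the scatter, so in this assay the change from compound 3 to compound 4 is expected to give no step beyond the scatter either, as a 1.1-fold lower number from compound 3 to compound 4 (0.03 log units; within the scatter). Compound 4 is therefore estimated at 6000 nM, with a range from 3000 nM to 12000 nM.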

Compound 4, half-maximal inhibitory concentration: 7030 nM
For compound 4 the middle estimate is 1.2-fold (0.07 log units) below the measured one; low and high end bracket the measured number.
By their numbers in this assay, from the lowest: compounds 1, 3, 4 and 2 (each within the scatter of the next).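

In this assay, the aromatic carbon two atoms from the ring oxygen accepts a far larger group without a readable shift: benzylcarbamoyl brings many more heavy atoms and an aromatic ring in place of the single heavy atom of amino, giving a 1.1-fold higher number from compound 3 to compound 4 (0.04 log units; within the scatter) and so adding a plain amide to the two substituted ones seen before. Changes on the amide side behave alike, with hydrogen in place of methoxy on an aromatic carbon giving a 1.2-fold higher number from compound 1 to compound 4 (0.07 log units; within the scatter) and phenyl in place of 2-(4-fluorophenyl)ethyl giving a 1.3-fold lower number from compound 2 to compound 4 (0.10 log units; within the scatter) as the reading. All four groups at this position therefore stand within the scatter of one another, and no measurement at hand offers an explanation for this.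

Going by these compounds, what remains open is whether any group at this position can move the number beyond the scatter, for example a carboxylic acid, or an amide carrying a piperidine ring. On these data alone, it is also open whether an amide without the amide hydrogen, such as an N,N-dimethyl amide, would behave in the same way.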